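The source may hold more compounds than are shown below. What is called first, only, known or untested is meant among the compounds shown, and "the series" means these compounds.

Among the compounds with values here, in a functional assay on MDA-MB-468 cells (Homo sapiens) for inhibition, read by sulforhodamine B assay, with a stated time of 48 h, tested at 1 uM (a lower number here means a stronger effect, a higher number a weaker effect of the compound at the concentration tested), compound 3 `COc1cc(Cl)cc(-c2nn(-c3cccc(NC(=O)Nc4ccc(Cl)c(C(F)(F)F)c4)c3)cc2-c2ccncc2)c1` gives 50%, the lowest of the three numbers measured so far. Compound 2 `O=C(Nc1cccc(-n2cc(-c3ccncc3)c(-c3cc(O)cc(Cl)c3)n2)c1)Nc1ccc(Cl)c(Cl)c1` gives 59%, a number within the scatter of compound 3, while compound 1 `O=C(Nc1cccc(-n2cc(-c3ccncc3)c(-c3cc(O)cc(Cl)c3)n2)c1)Nc1ccc(Cl)c(C(F)(F)F)c1` gives 75%, which stands above compound 3 beyond the scatter. Both measured steps start from compound 1: there was a number 16 percentage points lower from compound 1 to compound 2 (beyond the scatter), and there was a number 25 percentage points lower from compound 1 to compound 3 (beyond the scatter). Compound 4 `COc1cc(Cl)cc(-c2nn(-c3cccc(NC(=O)Nc4cccc(C(F)(F)F)c4)c3)cc2-c2ccncc2)c1` differs from compound 3 in one place: hydrogen in place of chloro on an aromatic carbon The chloro that leaves sits ortho to a trifluoromethyl group on a six-membered aromatic ring of carbon only, and in the same ring where the step from compound 1 to compound 2 was made, though that step exchanged groups rather than removing one. Within the data shown here, no measured step removes a chloro, so nothing bears directly on this change. The two steps seen were modest, and a change of one heavy atom with no ring and no donor or acceptor gives no reason to expect more than that here. Compound 4 is therefore expected to give about 55% in this assay, with an estimated range from 35% to 75%. The expected step is a number 5 percentage points higher from compound 3 to compound 4 (within the scatter), a change that may well stay within the scatter.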

Compound 4, a percentage reported as activity, at one concentration (the size of the read-out at that concentration, not a potency): 51%
Compound 4: middle estimate off by 4 percentage points, on the high side; the range from low to high includes it.
By their numbers in this assay, from the lowest: compounds 3, 4 and 2 (each within the scatter of the next); then compound 1.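

In this assay, going from the 4-chloro-3-(trifluoromethyl)phenyl group to the 3-(trifluoromethyl)phenyl group gives a number 1 percentage points higher from compound 3 to compound 4 (within the scatter), so this single pair shows no measurable effect of losing the chloro. Within the data shown here, the earlier steps concerned the trifluoromethyl place and the oxygen substituent, and both moved the number beyond the scatter, whereas this is the first look at the place ortho to a trifluoromethyl group and para to a large group, and here the chloro can give way to hydrogen without a change that can be told from the scatter. Nothing available explains why this place behaves as it does, and a read-out at a single concentration does not show whether potency is equally unaffected.

The compounds shown leave open whether the same exchange would read alike in compound 1, which carries a free hydroxyl where compound 3 carries a methoxy group, since the effect of a change at one place may depend on what stands elsewhere in the molecule. They also leave open what a larger or charged group would do at this place, such as an amine, a carboxylic acid or a longer alkyl chain in place of the chloro.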